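This account rests on a few compounds, and the source may have more. Where it says the series, first, only, none or still open, it means among the compounds named here.

The three measured compounds were tested in a functional assay on HO8910 cells (Homo sapiens) for cytotoxicity, read by CCK-8 assay, with a stated time of 24 h; on this read-out higher numbers stand for weaker inhibition and lower numbers for stronger inhibition:

Compound 1, `C/C(=C\c1cc(-c2ccc(C)cc2)co1)C(N)=O`, gives 24200 nM.
Compound 2, `C/C(=C\c1cc(-c2ccc(F)cc2)co1)C(N)=O`, gives only a limit of the assay, > 50000 nM.
Compound 3, `C/C(=C\c1cc(-c2ccc(C)nc2)co1)C(N)=O`, gives only a limit of the assay, > 50000 nM.

Compound 1 and compound 2 share a core and differ in one place: fluoro in place of methyl on an aromatic carbon. This change produced an at least 2.0-fold higher number from compound 1 to compound 2 (0.31 log units; beyond the scatter), so the fluoro compound inhibits less strongly, with the result sitting at the limit of > 50000 nM in this assay, at which 2 of the 3 values shown sit.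

Compound 3 carries a different core; how the core of compound 3 differs from that of compound 1 is not broken down here. Compound 4, `C/C(=C\c1cc(-c2ccc(F)nc2)co1)C(N)=O`, has not yet been measured. It stands to compound 3 as compound 2 stands to compound 1: fluoro in place of methyl on an aromatic carbon. The surroundings are not identical, though. In compound 1 the change sits on a six-membered aromatic ring of carbon only, para to a large group, whereas in compound 3 it sits on a six-membered aromatic ring with 1 nitrogen, next to the ring nitrogen and para to a large group. It is therefore the same kind of change, not the same change.

For compound 4 the expected step is a step that the limit leaves unreadable from compound 3 to compound 4, an expectation resting on compound 3 already giving only a limit, > 50000 nM, and on the weakening seen in an at least 2.0-fold higher number from compound 1 to compound 2 (0.31 log units; beyond the scatter). Compound 4 is accordingly expected to reach about 70000 nM, most likely again reported only as a limit, with a range estimated from 35000 nM to 200000 nM.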

Compound 4, half-maximal inhibitory concentration: 30000 nM
Compound 4: the middle estimate sits 2.3-fold (0.37 log units) above what was measured, and the stated range ends above it.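

In this assay, putting fluoro in place of methyl on the ring with one nitrogen gives an at least 1.6-fold lower number from compound 3 to compound 4 (0.22 log units; that floor lies within the scatter), so the weakening seen with this change on the core of compound 1 does not recur here, although the floor of this new step alone lies within the scatter. Set side by side, the two steps differ, so in this series the change cannot simply be carried from one core to another with its direction and size kept: the same change on two cores in this assay, an at least 2.0-fold higher number (0.31 log units; beyond the scatter) from compound 1 to compound 2 and an at least 1.6-fold lower number (0.22 log units; that floor lies within the scatter) from compound 3 to compound 4, at least 3.4-fold (0.53 log units) apart, beyond the scatter of two such steps This rests on a single pair for each core, does not show why the outcome differs, and gives the true size of neither step, as compound 2 and compound 3 each give only a limit rather than a number: the limit of > 50000 nM in this assay, at which 2 of the 4 values shown sit.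

Going by these compounds, it remains open whether the ring nitrogen itself accounts for the different outcome, or whether its place relative to the changed group matters. Also open, on these data alone, is how other groups at this place, such as a chloro, a methoxy or an amine, would behave on each of the two cores.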